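A few compounds are considered here, and "the series" means these few. Any claim that something is new, unique, unknown or untested is made for them only; others in the source may bear on it.

The measured compounds:
Compound 1 `CCN(CC)CCNC(=O)c1ccc(C(CC)(CC)c2ccc(OCC(O)C(C)(C)C)c(C)c2)n1CC` gives 6.54 nM in an assay on cells for agonist activity at vitamin D3 receptor (Homo sapiens), read by microscopy; on this read-out higher numbers stand for an effect only at larger amounts of compound and lower numbers for an effect already at smaller amounts.
Compound 2 `CCCCC(=O)c1ccc(C(CC)(CC)c2ccc(C#CC(O)(CC)CC)c(C)c2)n1CC` reaches only a limit of this assay, > 50 nM.
Compound 3 `CCn1cc(C(CC)(CC)c2ccc(C#CC(O)(CC)CC)c(C)c2)cc1C(=O)NCCN(C)C` gives 19.3 nM in this assay.

Of the two numbers that this assay returns, compound 3 stands at the higher one, while compound 1 sits at the lower, and the gap between the two lies beyond the usual scatter of repeated measurements. The third value is a limit only (the limit of > 50 nM in this assay, at which 1 of the 3 values shown sits), so it says nothing about where compound 2 falls beyond that bound. For the measured compounds named here, compound 1 and compound 3 differ from each other in several places at once, so no single structural step between measured compounds can be read from these numbers.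

Compound 4 `CCn1cc(C(CC)(CC)c2ccc(C#CC(O)(CC)CC)c(C)c2)cc1C(=O)N[C@H](C(=O)O)C(C)C` departs from compound 3 in one place: 1-carboxy-2-methylpropyl in place of 2-(dimethylamino)ethyl on an amide-type nitrogen. Going by the values given here, no measured pair shows what this exchange on the amide-type nitrogen does in this assay, and the rest of the structure stays as in compound 3. Without a measured step to lean on, a modest shift towards higher numbers is expected, a 1.6-fold higher number from compound 3 to compound 4 (0.19 log units; within the scatter), though a result within the scatter of compound 3 would not surprise. Compound 4 is therefore estimated at 30 nM, with a plausible range from 8 nM to 120 nM.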

Compound 4, half-maximal effective concentration: 12.7 nM
The estimate for compound 4 lay 2.4-fold (0.37 log units) above the measured number; the measured number falls inside the stated range.
By their numbers in this assay, from the lowest: compounds 1, 4 and 3 (each within the scatter of the next, the first and the last beyond it). At a limit, above all of these: compound 2.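

In this assay, for the compounds shown here, replacing 2-(dimethylamino)ethyl with 1-carboxy-2-methylpropyl on the amide-type nitrogen gives a 1.5-fold lower number from compound 3 to compound 4 (0.18 log units; within the scatter), and this is the first single-place step available. In this pair, the dimethylamino group is therefore not required for a number of this size: a larger group carrying a carboxy group and a defined stereocentre leaves the result within the scatter of compound 3. The data shown give no reason for this outcome.

From the compounds shown here alone, it remains open whether a shorter chain ending in a carboxylic acid, a longer one, a primary amide or the mirror-image form of the 1-carboxy-2-methylpropyl group would give a similar number on this amide-type nitrogen. Going by these compounds, it is also open whether the same exchange would give a comparable step with the other parts of the structure changed, such as the 3-hydroxy-3-ethylpentynyl chain, since this single pair shows the exchange in only one structural setting.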